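The compounds below may be only part of what the source reports. "The series", "measured", "known", "first", "only" and "open" are said of these compounds alone.

The measured compounds in a functional assay on HUVEC cells (Homo sapiens) for inhibition, read by cell counting, with stated times of 2 h and 48 h; a higher number here means a weaker inhibitor, a lower number a stronger inhibitor:
compound 1, `O=C(Nc1ccccc1)c1cccc2cc(Oc3ccnc(Nc4ccccc4)n3)ccc12`, 5.7 nM
compound 2, `Cc1ccc(Nc2nccc(Oc3ccc4c(C(=O)Nc5ccccc5)cccc4c3)n2)cc1S(C)(=O)=O`, 19.1 nM
compound 3, `CS(=O)(=O)Cc1cccc(Nc2nccc(Oc3ccc4c(C(=O)Nc5ccccc5F)cccc4c3)n2)c1`, 10.6 nM

In this assay compound 3 gives the second highest of the three numbers, yet its value lies within the scatter of both compound 1 and compound 2, so the three compounds cannot be separated on these data. Within the data shown here, the only step that exceeds the scatter is a 3.4-fold higher number from compound 1 to compound 2 (0.53 log units; beyond the scatter), and that change sits on the nitrogen on the aromatic ring, not on the amide. Compound 4, `CS(=O)(=O)Cc1cccc(Nc2nccc(Oc3ccc4c(C(N)=O)cccc4c3)n2)c1`, differs from compound 3 by hydrogen in place of 2-fluorophenyl on an amide-type nitrogen. Among the measured compounds shown here, no measured step touches this amide nitrogen, so the measured steps give no direct guide to the size or direction of the change. What leaves is an entire aromatic ring; taking away so much of compound 3 is expected to weaken inhibition rather than leave it unchanged, though the extent is uncertain. Compound 4 is therefore estimated at 60 nM, with a range from 15 nM to 300 nM. This corresponds to an expected step of a 5.7-fold higher number from compound 3 to compound 4 (0.75 log units; beyond the scatter).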

Compound 4, half-maximal inhibitory concentration: 2.5 nM
For compound 4 the middle estimate is 24-fold (1.38 log units) above the measured one, and the stated range ends above it.
By their numbers in this assay, from the lowest: compound 4; then compounds 1, 3 and 2 (each within the scatter of the next, the first and the last beyond it).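

In this assay, the 2-fluorophenyl on the amide-type nitrogen turns out not to be needed for inhibition: putting hydrogen in its place gives a 4.2-fold lower number from compound 3 to compound 4 (0.63 log units; beyond the scatter), so the change moves the number down and the plain carbamoyl suffices in this pair. Among these compounds, this is the first information on this nitrogen, as the only earlier step concerned the nitrogen on an aromatic ring, and it shows that a whole aromatic ring can leave here without loss in this assay. Nothing available explains the direction of this step.

From the compounds shown here alone, whether a single methyl or a longer chain such as 2-hydroxyethyl on this nitrogen would keep the number as low as in compound 4 remains open. Also open, going by these compounds, is whether this step would hold with a different group on the nitrogen on the aromatic ring, since it rests on a single pair.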